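Swapping an ester for a thiophene ring on the chain

The compounds below may be only part of what the source reports. "The series", "measured", "known", "first", "only" and "open" are said of these compounds alone.

Of the compounds shown here, three sharing one core have been measured in a functional assay for inhibition, with Homo sapiens as the target; a higher number here means a weaker inhibitor, a lower number a stronger inhibitor. Compound 1 `CCOC(=O)/C(=C\c1cccc(OCC(=O)O)c1)c1nc(-c2ccccc2)c(-c2ccccc2)o1` gives 360 nM. Among the measured compounds shown here, compound 2 `O=C(O)COc1cccc(/C=C(\C(=O)O)c2nc(-c3ccccc3)c(-c3ccccc3)o2)c1` gives 20300 nM, and the only single-change step known here, a 56-fold higher number from compound 1 to compound 2 (1.75 log units; beyond the scatter), is a large one. Compound 3 `CC(C)OC(=O)C(Cc1cccc(OCC(=O)O)c1)c1nc(-c2ccccc2)c(-c2ccccc2)o1` gives 1220 nM, the second highest of the three numbers: compound 1 stands nearest with a lower number, and compound 2 furthest with a higher one, both gaps beyond the scatter.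

Compound 4 `O=C(O)COc1cccc(CC(c2ccsc2)c2nc(-c3ccccc3)c(-c3ccccc3)o2)c1` has not been measured. It differs from compound 3 in one place: thiophen-3-yl in place of isopropoxycarbonyl on a saturated chain carbon bound to an aromatic carbon and a saturated chain carbon. For the measured compounds named here, the one measured step, a 56-fold higher number from compound 1 to compound 2 (1.75 log units; beyond the scatter), alters the ester but keeps its carbonyl, whereas here the whole isopropoxycarbonyl leaves and an aromatic ring enters, so no measured step covers this change directly. Some loss of potency is taken as the more likely outcome, with wide uncertainty. Compound 4 is expected to give 2500 nM, within 600 nM to 10000 nM. That estimate corresponds to an expected 2.0-fold higher number from compound 3 to compound 4 (0.31 log units; beyond the scatter).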

Compound 4, half-maximal inhibitory concentration: 20700 nM
Compound 4: the middle estimate sits 8.3-fold (0.92 log units) below what was measured; the whole stated range lies below it.
By their numbers in this assay, from the lowest: compound 1; then compound 3; then compounds 2 and 4 (each within the scatter of the next).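

On this saturated chain carbon, the isopropoxycarbonyl group cannot be exchanged for a thiophen-3-yl ring without a heavy cost: in this assay the swap gives a 17-fold higher number from compound 3 to compound 4 (1.23 log units; beyond the scatter), a much weaker inhibitor. The earlier step changed the ester but kept its carbonyl, while this one removes the whole ester, and it shows that a group of similar heavy-atom count (five against six) does not preserve inhibition here. Nothing available explains the loss.

Still open, on these data alone, is whether the loss follows from removing the ester's carbonyl and oxygens or from bringing in the thiophene ring. An amide at this carbon, which would retain a carbonyl, and a plain phenyl ring, which would offer a different aromatic group, could help separate those two possibilities.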